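Amide cap variation in a kinase inhibitor series

This account rests on a few compounds, and the source may have more. Where it says the series, first, only, none or still open, it means among the compounds named here.

For the measured compounds named here, in an assay on isolated protein for inhibition of Rho-associated protein kinase 1 (Homo sapiens), read by scintillation counting, radiometric assay and 33P incorporation, with a stated time of 40 min, in the presence of a further agent that is not named here (a higher number here means a weaker inhibitor, a lower number a stronger inhibitor), compound 2 `CC(=O)Nc1cccc(NC(=O)COc2ccc3c(=O)ccoc3c2)c1` gives 2500 nM, the only numeric reading in the set. Compound 1 `Cc1c(OCC(=O)Nc2cccc(NC(=O)c3ccc(N(C)C)cc3)c2)ccc2c(=O)ccoc12`, which bears an aromatic amide cap, returns only a limit at > 10000 nM. Compound 3 `Cc1cc(C(=O)Nc2cccc(NC(=O)COc3ccc4c(=O)ccoc4c3)c2)no1` differs from compound 2 by 5-methyl-1,2-oxazol-3-yl in place of methyl on a carbonyl carbon. Going by the values given here, no measured step between these two exists, so the expectation leans on compound 1 sitting at the limit of > 10000 nM in this assay, at which 1 of the 2 values shown sits, with an aromatic cap of its own; the expected step of a 2.0-fold higher number from compound 2 to compound 3 (0.30 log units; within the scatter) is therefore a loss of potency beyond the scatter. Compound 3 is estimated at 5000 nM, within 2000 nM to 15000 nM, with a real chance that only a limit is reported.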

Compound 3, half-maximal inhibitory concentration: 68 nM
Compound 3: middle estimate off by 74-fold (1.87 log units), on the high side, outside the stated range (below it).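

On the carbonyl carbon, 5-methyl-1,2-oxazol-3-yl in place of methyl gives a 37-fold lower number from compound 2 to compound 3 (1.57 log units; beyond the scatter) in this assay and so makes this position a strong lever on potency. Compound 1 differs from compound 3 in more than one place, so its limit does not bear on this change alone. Nothing on hand accounts for the gain.

From the compounds shown here alone, whether the step comes from the ring, its hetero atoms or its methyl stays open. An unsubstituted 1,2-oxazol-3-yl, a phenyl or a cyclopropyl on the same carbonyl carbon would separate these.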